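The source may hold more compounds than are shown below. What is called first, only, known or untested is meant among the compounds shown, and "the series" means these compounds.

Values in an ADME assay on MT4 cells (Homo sapiens) for cytotoxicity, read by XTT assay, with a stated time of 5 days; a higher number here means that more compound is tolerated, a lower number that less compound is tolerated:
Compound 1 `CNC(=O)[C@@H](NC(=O)[C@@](O)(CCCN(Cc1ccc(Br)cc1)NC(=O)[C@@H](NC(=O)OC)C(C)(C)C)Cc1ccccc1)C(C)(C)C`: > 10000 nM, a limit.
Compound 2 `CNC(=O)[C@@H](NC(=O)[C@@](O)(CCCN(Cc1ccc(-c2ccncc2)cc1)NC(=O)[C@@H](NC(=O)OC)C(C)(C)C)Cc1ccccc1)C(C)(C)C`: > 50000 nM, a limit.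
Compound 3 `CNC(=O)[C@@H](NC(=O)[C@@](O)(CCCN(Cc1ccc(C#Cc2ccccn2)cc1)NC(=O)[C@@H](NC(=O)OC)C(C)(C)C)Cc1ccccc1)C(C)(C)C`: > 50000 nM, a limit.

Among the compounds with values here, no compound has yet given a number. Compound 3 reads > 50000 nM, which is a limit, and it belongs with the limit of > 50000 nM in this assay, at which 2 of the 3 values shown sit. Compound 1 instead belongs with the limit of > 10000 nM in this assay, at which 1 of the 3 values shown sits.

The next compound is compound 4 `CNC(=O)[C@@H](NC(=O)[C@@](O)(CCCN(Cc1ccc(C#Cc2cccnc2)cc1)NC(=O)[C@@H](NC(=O)OC)C(C)(C)C)Cc1ccccc1)C(C)(C)C`, and the change is pyridin-3-yl in place of pyridin-2-yl on a triple-bonded carbon.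

The measured steps that bear on it are a step that the two limits leave unreadable from compound 2 to compound 3, a step that the two limits leave unreadable from compound 1 to compound 3 and a step that the two limits leave unreadable from compound 1 to compound 2. None of them has a readable size, so no measured size can be carried over to this change. No step beyond the scatter is expected in this assay, in either direction, and the expected step is a number no higher from compound 3 to compound 4 (the limit leaves the size open).

Compound 4 is estimated at 50000 nM, with an expected range of 20000 nM to 100000 nM, and it is likely to be reported only as a limit.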

Compound 4, half-maximal cytotoxic concentration: > 50000 nM
Compound 4 was reported as a limit; the forecaster's own chance of this, stated with the estimate: 85%; the middle value lies on the limit itself.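

In this assay compound 4 reads > 50000 nM, a limit. Its steps from compound 1, compound 2 and compound 3 all join two limits and cannot be read. The compounds shown leave open at what concentration any of them becomes cytotoxic, and whether pyridin-3-yl and pyridin-2-yl differ at all.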